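A Fourth Compound in a Flat Series

A few compounds are considered here, and "the series" means these few. Any claim that something is new, unique, unknown or untested is made for them only; others in the source may bear on it.

Compound 3 `O=C(N/N=C\c1cccc(O)c1)Nc1nnc(COc2ccc3ccccc3c2)o1` sits level with its two relatives in a functional assay on the whole organism (strain Swiss albino) with Mus musculus as the target, in the maximal electroshock model, with a stated time of 4 h; a higher number here means that more compound is needed for the effect, a lower number that less compound is needed: compound 1 `O=C(N/N=C\c1ccccc1)Nc1nnc(COc2ccc3ccccc3c2)o1` gives 300 mg/kg, compound 2 `C/C(=N/NC(=O)Nc1nnc(COc2ccc3ccccc3c2)o1)c1ccc(N)cc1` gives 300 mg/kg, and compound 3 gives 300 mg/kg. Every step among them stayed within the scatter: no change at the digits printed from compound 1 to compound 2 (within the scatter), no change at the digits printed from compound 1 to compound 3 (within the scatter) and no change at the digits printed from compound 2 to compound 3 (within the scatter). Compound 4 `C/C(=N/NC(=O)Nc1nnc(COc2ccc3ccccc3c2)o1)c1ccc(O)cc1` differs from compound 3 by a group of 10 heavy atoms (8 carbon, 1 nitrogen, 1 oxygen; one six-membered aromatic ring of carbon only) in place of a group of 9 heavy atoms (7 carbon, 1 nitrogen, 1 oxygen; one six-membered aromatic ring of carbon only), on an amide-type nitrogen. The step from compound 1 to compound 2 bears most directly on this, as that change also swapped the group on the amide-type nitrogen and left the dose where it was. The step from compound 3 to compound 4 is therefore expected to be no change at the digits printed from compound 3 to compound 4 (within the scatter), nothing beyond the scatter. Compound 4 is estimated at 300 mg/kg, within 150 mg/kg to 600 mg/kg.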

Compound 4, minimum effective dose: 300 mg/kg
Beside the measured number, compound 4's estimate shows no gap at the digits printed; the measured number falls inside the stated range.
By their numbers in this assay, from the lowest: compounds 1, 2, 3 and 4 (each within the scatter of the next).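

The group on the amide-type nitrogen takes yet another form here, and the reading still shows no change at the digits printed from compound 3 to compound 4 (within the scatter) and no change at the digits printed from compound 1 to compound 4 (within the scatter) in this series. Hydroxy in place of amino on an aromatic carbon, a swap the earlier compounds did not offer, gives no change at the digits printed from compound 2 to compound 4 (within the scatter) as well. Nothing measured here accounts for this flat result.

As far as these compounds go, whether a carboxylic acid or a dimethylamino group on that aromatic ring would shift the dose remains open. The compounds shown also leave open what a change to the shared core would do.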